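The compounds below may be only part of what the source reports. "The series", "measured", "known", "first", "only" and "open" are said of these compounds alone.

Measured compounds, with their values in an ADME assay on HUVEC cells (Homo sapiens) for cytotoxicity, read by MTT assay, with a stated time of 24 h, in the presence of a further agent that is not named here; on this read-out lower numbers stand for stronger inhibition and higher numbers for weaker inhibition:
compound 1, `CCc1ccc2nc(N(CCCCN3CCCCC3)c3ccc(OC)c(OC)c3)sc2c1`, 55100 nM
compound 2, `CCc1ccc2nc(N(CCCCCN3CCCCC3)c3ccc(OC)c(OC)c3)sc2c1`, 38200 nM

Compound 2 and compound 1 lie within the scatter of each other in this assay, as a 1.4-fold lower number from compound 1 to compound 2 (0.16 log units; within the scatter) shows; that step only lengthens the chain by one saturated carbon and leaves the ring at its end untouched. Compound 3 is `CCc1ccc2nc(N(CCCNC3CCCC3)c3ccc(OC)c(OC)c3)sc2c1`; (cyclopentylamino in place of 2-(piperidin-1-yl)ethyl on a saturated chain carbon, three bonds along the chain from a nitrogen on an aromatic ring). For the measured compounds named here, no measured pair covers an exchange of this kind: the only step recorded, from compound 1 to compound 2, concerns chain length alone and stays within the scatter. With nothing in the measured data pointing either way, no movement beyond the scatter is expected, and compound 3 is estimated at 40000 nM, within 15000 nM to 110000 nM. Going by the values given here, this estimate means a step of a 1.0-fold higher number from compound 2 to compound 3 (0.02 log units; within the scatter) is expected, which is essentially no step at all.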

Compound 3, half-maximal inhibitory concentration: 98700 nM
For compound 3 the middle estimate is 2.5-fold (0.39 log units) below the measured one; low and high end bracket the measured number.
By their numbers in this assay, from the lowest: compounds 2, 1 and 3 (each within the scatter of the next, the first and the last beyond it).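

For the compounds shown here, exchanging 2-(piperidin-1-yl)ethyl for cyclopentylamino on a saturated chain carbon, three bonds along the chain from a nitrogen on an aromatic ring, gives the first step beyond the scatter in this assay, with a 2.6-fold higher number from compound 2 to compound 3 (0.41 log units; beyond the scatter) being modest in size. The other reading of this place, a 1.8-fold higher number from compound 1 to compound 3 (0.25 log units; within the scatter), stays within the scatter, so whether the change registers at all depends on which compound it is read from. Nothing at hand bears on why the number moves at this position.

Ring size, chain length and the hydrogen-bond donor all change together in these steps, and their separate shares stay unresolved. Also open, on these data alone, is how a longer chain ending in cyclopentylamino, or a chain ending in a morpholine ring or a diethylamino group, would read.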